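The compounds below may be only part of what the source reports. "The series", "measured", "known", "first", "only" and "open" are said of these compounds alone.

Measured compounds:
Compound 1 `CC(=O)OC/C(=C\c1ccccc1)C(=O)c1ccccc1` gives 17000 nM in a functional assay on HBL-100 cells (Homo sapiens) for inhibition, read by sulforhodamine B assay, with a stated time of 48 h; on this read-out lower numbers stand for stronger inhibition of growth and higher numbers for weaker inhibition of growth.
Compound 2 `CC(=O)OC/C(=C\c1ccc(Cl)cc1)C(=O)c1ccccc1` gives 2300 nM in this assay.
Compound 3 `CC(=O)OC/C(=C/c1ccc(Cl)cc1)C(=O)c1ccc(Cl)cc1` gives 16000 nM in this assay.

Compound 1 and compound 2 differ by chloro in place of hydrogen on an aromatic carbon, and this change brought a 7.4-fold lower number from compound 1 to compound 2 (0.87 log units; beyond the scatter). Compound 3 carries a chloro group on each of its two rings; how its core differs from that of compound 1 is not broken down here. The values of compound 3 and compound 1 in this assay lie within the scatter of each other, so no order between them can be read.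

Compound 4 `CC(=O)OC/C(=C/c1ccc(Cl)cc1Cl)C(=O)c1ccc(Cl)cc1` has not yet been measured. It differs from compound 3 by chloro in place of hydrogen on an aromatic carbon. Going by the values given here, this is the same kind of change as the one from compound 1 to compound 2, but not the same: there the chloro entered para to a large group, here it enters ortho to a large group and meta to a chloro group. Among the compounds with values here, the only guide is the step from compound 1 to compound 2, a 7.4-fold lower number from compound 1 to compound 2 (0.87 log units; beyond the scatter), which sets the scale. The step from compound 3 to compound 4 is therefore expected to be a 2.0-fold lower number from compound 3 to compound 4 (0.30 log units; within the scatter), though the different place makes this uncertain. Compound 4 is estimated at 8000 nM, between 2500 nM and 25000 nM.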

Compound 4, concentration for 50% growth inhibition: 22000 nM
The estimate for compound 4 lay 2.8-fold (0.44 log units) below the measured number, and the stated range covers the measured number.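

In this assay, putting a chloro group in place of hydrogen on compound 3 gave a 1.4-fold higher number from compound 3 to compound 4 (0.14 log units; within the scatter), so on this core the change brought no shift that can be read. Set beside the earlier step, the same change did not carry over from one core to the other: the same change on two cores in this assay, a 7.4-fold lower number (0.87 log units; beyond the scatter) from compound 1 to compound 2 and a 1.4-fold higher number (0.14 log units; within the scatter) from compound 3 to compound 4, 10-fold (1.01 log units) apart, beyond the scatter of two such steps. This does not show what sets the two steps apart, since the cores differ and the chloro group also sits in a different place, here ortho to a large group and meta to a chloro group, and two pairs cannot separate these factors.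

From the compounds shown here alone, it remains open whether a chloro group entering the same place on both cores would give matching steps. Going by these compounds, it is also open how other groups on the same ring, such as an amine or a carboxylic acid, would behave on these two cores.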